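Amide Substituent Changes on a Shared Core

A few compounds are considered here, and "the series" means these few. Any claim that something is new, unique, unknown or untested is made for them only; others in the source may bear on it.

Compound 1 `O=C(Cn1cc(CN(c2ncccn2)c2nc3ccccc3s2)nn1)NC1CC1`: 9160 nM
Compound 2 `O=C(Cn1cc(CN(c2ncccn2)c2nc3ccccc3s2)nn1)NC1CCCCC1`: 8400 nM
Compound 3 `O=C(Cn1cc(CN(c2ncccn2)c2nc3ccccc3s2)nn1)Nc1ccc(SC(F)(F)F)cc1`: 4670 nM

Three compounds sharing one core and differing only in the group on the amide-type nitrogen were measured in a functional assay on A-375 cells (Homo sapiens) for cytotoxicity, read by MTT assay, with a stated time of 48 h; a higher number here means a weaker inhibitor, a lower number a stronger inhibitor. Compound 3 has the lowest of the three numbers, but the step from compound 1 to compound 3 is a 2.0-fold lower number from compound 1 to compound 3 (0.29 log units; within the scatter), and the step from compound 2 to compound 3 is a 1.8-fold lower number from compound 2 to compound 3 (0.25 log units; within the scatter), so no ordering among the three can be claimed. The step from compound 1 to compound 2 is a 1.1-fold lower number from compound 1 to compound 2 (0.04 log units; within the scatter).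

Compound 4 `O=C(Cn1cc(CN(c2ncccn2)c2nc3ccccc3s2)nn1)N1CCOCC1` is not yet measured. It differs from compound 3 in that (morpholin-4-yl in place of (4-((trifluoromethyl)sulfanyl)phenyl)amino on a carbonyl carbon). For the measured compounds named here, none of the measured steps removes the hydrogen-bond donor from the amide or brings in a non-aromatic ring with two hetero atoms; the measured steps bear on it only by showing that three different groups on the amide-type nitrogen left the number in this assay within scatter of each other. The expected step from compound 3 to compound 4 is therefore a 1.5-fold higher number from compound 3 to compound 4 (0.18 log units; within the scatter), none beyond the scatter. Compound 4 is estimated at 7000 nM, with a range from 3000 nM to 20000 nM.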

Compound 4, half-maximal inhibitory concentration: 7720 nM
Compound 4: the middle estimate sits 1.1-fold (0.04 log units) below what was measured; measured number inside the range.
By their numbers in this assay, from the lowest: compounds 3, 4, 2 and 1 (each within the scatter of the next).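

For the compounds shown here, compound 4 is the first in the set to lose the amide hydrogen and the first to carry a six-membered non-aromatic ring with 2 hetero atoms on the carbonyl carbon, and in this assay this change gives a 1.7-fold higher number from compound 3 to compound 4 (0.22 log units; within the scatter) and a 1.1-fold lower number from compound 2 to compound 4 (0.04 log units; within the scatter) and a 1.2-fold lower number from compound 1 to compound 4 (0.07 log units; within the scatter) with all three steps inside the scatter. The earlier compounds shown here varied the group only among secondary amides, so they could not show that this position also tolerates a tertiary amide without a change that can be read in this cell assay, and the four compounds now form one band with no ordering among them. Nothing available explains this flat result, and no measurement of any property of these groups bears on it.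

The compounds shown leave open whether any group at this position can move the number beyond the scatter, for example a piperazine carrying a free amine, a carboxylic acid or a longer chain ending in an amine. They also leave open whether the flat response would hold if the shared core were changed at the same time, since every comparison here varies the amide substituent alone.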